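A few compounds are considered here, and "the series" means these few. Any claim that something is new, unique, unknown or untested is made for them only; others in the source may bear on it.

Among the measured compounds shown here, compound 2, whose structure is `O=C(Nc1cccc(CNc2nccnc2Cl)c1)Nc1ccccc1F`, is the only compound of this small set with a numerical result in a functional assay on T-24 cells (Homo sapiens) for antiproliferative activity, read by MTT assay, with a stated time of 48 h (a lower number here means a stronger inhibitor, a higher number a weaker inhibitor), where compound 2 gives 7450 nM. Compound 1, with the structure `O=C(Nc1cccc(CNc2nccnc2Cl)c1)Nc1cccc2ccccc12`, reaches only a limit of the assay: in this assay compound 1 gives > 40000 nM, which is a limit and not a number. Within the numbers shown, then, compound 2 stands as the one measured value, with the other entry sitting at the limit described by the limit of > 40000 nM in this assay, at which 1 of the 2 values shown sits.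

Compound 3, with the structure `CN(C)c1ccc(NC(=O)Nc2cccc(CNc3nccnc3Cl)c2)cc1`, has not yet been measured in this assay. It differs from compound 2 in one place: 4-(dimethylamino)phenyl in place of 2-fluorophenyl on an amide-type nitrogen. For the measured compounds named here, no step between two measured compounds exists that would show what such a change does, so the expected step is set as no more than a small shift, in either direction, beyond the scatter. The estimated step of a 1.3-fold higher number from compound 2 to compound 3 (0.13 log units; within the scatter) reflects this uncertainty. In this assay compound 3 is expected to give about 10000 nM, with a range from 2500 nM to 40000 nM.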

Compound 3, half-maximal inhibitory concentration: 20200 nM
Compound 3: the middle estimate sits 2.0-fold (0.31 log units) below what was measured, within the range that was stated.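

In this assay, among the compounds shown here, 4-(dimethylamino)phenyl in place of 2-fluorophenyl on an amide-type nitrogen gives a 2.7-fold higher number from compound 2 to compound 3 (0.43 log units; beyond the scatter), the first step that can be read at this position, and it shows that activity here changes with the group the nitrogen carries. Compound 3 still gives a number, 20200 nM, so the position now has two measured points rather than one. Compound 1 remains a limit and not a number, so its distance from the other compounds cannot be read as a step: the limit of > 40000 nM in this assay, at which 1 of the 3 values shown sits.

For the compounds shown here, the single step exchanges a whole group, so it does not separate the loss of the fluorine from the arrival of the dimethylamino group, and it gives no cause for the change. On these data alone, how unsubstituted phenyl, 4-fluorophenyl or a phenyl ring bearing a carboxylic acid would read on this nitrogen stays open, as does whether any group here could give a number lower than that of compound 2.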